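Methyl to Trifluoromethyl on a Thiazole-Type Ring

The source may hold more compounds than are shown below. What is called first, only, known or untested is meant among the compounds shown, and "the series" means these compounds.

Of the compounds shown here, two sharing one core have been measured in a functional assay on CHO-K1 cells for antagonist activity at C-X-C chemokine receptor type 3 (Homo sapiens), read by FLIPR, with a stated time of 10 min; a lower number here means a stronger inhibitor, a higher number a weaker inhibitor. Compound 1 `C[C@H]1CN(c2scnc2-c2nc3ccccc3[nH]2)CCN1C(=O)Cn1cnc2cccnc21` gives 67 nM in this assay. Compound 2 `Cc1nc(-c2nc3ccccc3[nH]2)c(N2CCN(C(=O)Cn3cnc4cccnc43)[C@H](C)C2)s1` gives 9 nM in this assay and stands lowest of the two numbers, with compound 1 a clear distance above it, beyond the scatter.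

Compound 3 `C[C@@H]1CN(c2sc(C(F)(F)F)nc2-c2nc3ccccc3[nH]2)CCN1C(=O)Cn1cnc2cccnc21` is the next step from compound 2: trifluoromethyl in place of methyl on an aromatic carbon. Among the measured compounds shown here, no pair of measured compounds shows what such an exchange does here, so the direction of the step is open. A change of this kind on a small aromatic ring is expected to move the number only modestly in either sense, and in the absence of a comparable measured step the expected movement is placed close to none beyond the scatter. Compound 3 is therefore estimated at 15 nM in this assay, with a range from 4 nM to 60 nM, which corresponds to the expected step of a 1.7-fold higher number from compound 2 to compound 3 (0.22 log units; within the scatter).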

Compound 3, half-maximal inhibitory concentration: 1.6 nM
Compound 3: middle estimate off by 9.4-fold (0.97 log units), on the high side, outside the stated range (below it).
By their numbers in this assay, from the lowest: compound 3; then compound 2; then compound 1.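

Among the compounds shown here, at this position, the aromatic carbon next to the ring nitrogen and next to the ring sulfur, the exchange of methyl for trifluoromethyl is the first single-place change that can be read, and in this assay it gives a 5.6-fold lower number from compound 2 to compound 3 (0.75 log units; beyond the scatter). The step lies beyond the scatter, which shows that this carbon tolerates the larger trifluoromethyl group and that the number still responds to what sits there, with compound 3 the lowest of the three numbers. No measurement shown bears on the reason for this step.

From the compounds shown here alone, whether an ethyl, a cyclopropyl or a nitrile on this carbon would give a number nearer that of compound 2 or that of compound 3 remains open. A single step also cannot show whether the same exchange would have a similar effect on a different core.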